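The compounds below may be only part of what the source reports. "The series", "measured", "known", "first", "only" and "open" are said of these compounds alone.

Measured so far in a functional assay on DU-145 cells (Homo sapiens) for antiproliferative activity, read by propidium iodide staining, with a stated time of 96 h; a higher number here means a weaker inhibitor, a lower number a stronger inhibitor:
Compound 1, `CC(O)(CSc1cccc(S(F)(F)(F)(F)F)c1)C(=O)Nc1ccc(C#N)c(C(F)(F)F)c1`, gives 32700 nM.
Compound 2, `CC(O)(CSc1cccc(S(F)(F)(F)(F)F)c1)C(=O)Nc1ccc([N+](=O)[O-])c(C(F)(F)F)c1`, gives 13900 nM.
Compound 3, `CC(O)(CSc1ccc(S(F)(F)(F)(F)F)cc1)C(=O)Nc1ccc(C#N)cc1C(F)(F)F`, gives 17700 nM.

Compound 2 differs from compound 1 by one change, (nitro in place of cyano on an aromatic carbon), and the step it made was a 2.4-fold lower number from compound 1 to compound 2 (0.37 log units; beyond the scatter). Compound 4, `CC(O)(CSc1ccc(S(F)(F)(F)(F)F)cc1)C(=O)Nc1ccc([N+](=O)[O-])cc1C(F)(F)F`, is not yet measured. It differs from compound 3 by nitro in place of cyano on an aromatic carbon. Among the compounds with values here, this is the same kind of change as the one from compound 1 to compound 2, though not the same: in compound 1 the cyano sits ortho to a trifluoromethyl group, while in compound 3 it sits meta to a trifluoromethyl group. The difference between the core of compound 1 and the core of compound 3 is not broken down here; compound 3 has the same atoms as compound 1, joined differently. Because the earlier step was a 2.4-fold lower number from compound 1 to compound 2 (0.37 log units; beyond the scatter), a step of roughly that size is expected from compound 3 to compound 4, namely a 2.1-fold lower number from compound 3 to compound 4 (0.32 log units; beyond the scatter). For compound 4 the estimate in this assay is 8500 nM, expected to fall between 3500 nM and 20000 nM.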

Compound 4, half-maximal inhibitory concentration: 14500 nM
The estimate for compound 4 lay 1.7-fold (0.23 log units) below the measured number; the measured number falls inside the stated range.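

In this assay, putting nitro in place of cyano gave a 1.2-fold lower number from compound 3 to compound 4 (0.09 log units; within the scatter), so on this core the swap cannot be told apart from no change at all. The step on the other core was larger on paper, yet set side by side the two steps do not truly disagree: the same change on two cores in this assay, a 2.4-fold lower number (0.37 log units; beyond the scatter) from compound 1 to compound 2 and a 1.2-fold lower number (0.09 log units; within the scatter) from compound 3 to compound 4, 1.9-fold (0.28 log units) apart, within the scatter of two such steps

Within the data shown here, this fits the idea that the change carries over from one core to the other at a similar size, but it does not prove it: only two pairs of compounds stand behind it, and one of the two steps is too small to read on its own.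

The compounds shown hold only cyano and nitro at this place on the anilide ring, so what an amine or a carboxylic acid would do there stays open. On these data alone, it is also open whether the swap would behave the same way on a core with a sulfone in place of the thioether sulfur, or with a longer chain in the linker.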